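Amino acid amides on the shared core: towards compound 4

The source may hold more compounds than are shown below. What is called first, only, known or untested is meant among the compounds shown, and "the series" means these compounds.

For the measured compounds named here, the three measured members carry the core of compound 1 `O=C(CN(c1nc(Cl)nc2[nH]cnc12)C1CC1)NCC(=O)OCc1ccccc1` with different amino acid amides. In a functional assay on the whole organism (Tail, strain ICR) with Mus musculus as the target, in the tail flick test, with a stated time of 30 min, at a dose of 6.25 umol/kg by the oral route (on this read-out higher numbers stand for a stronger effect at the one dose given and lower numbers for a weaker effect), compound 1 gives 5.73%. Compound 3 `CC(C)[C@H](NC(=O)CN(c1nc(Cl)nc2[nH]cnc12)C1CC1)C(=O)OCc1ccccc1` gives 7.69%, and the step of a number 2 percentage points higher from compound 1 to compound 3 (within the scatter) stays within the scatter. Compound 2 `N=C(N)NCCC[C@H](NC(=O)CN(c1nc(Cl)nc2[nH]cnc12)C1CC1)C(=O)O` gives 8.9%, the highest of the three numbers, though its gaps to compound 3 and to compound 1 are both within the scatter. Compound 4 `NCCCC[C@H](NC(=O)CN(c1nc(Cl)nc2[nH]cnc12)C1CC1)C(=O)O` differs from compound 2 by a group of 2 heavy atoms (1 carbon, 1 nitrogen; no ring) in place of a group of 4 heavy atoms (1 carbon, 3 nitrogen; no ring), on a saturated chain carbon, four bonds along the chain from an amide-type nitrogen and a carbonyl carbon. Going by the values given here, no measured step touches this position; the only step seen, a number 2 percentage points higher from compound 1 to compound 3 (within the scatter), concerns another place and was within the scatter, and all three numbers sit close together. For compound 4 a step of a number 0.9 percentage points lower from compound 2 to compound 4 (within the scatter) is therefore expected, none beyond the scatter. Compound 4 is estimated at 8%, with a range from 0% to 18%.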

Compound 4, a percentage reported as activity, at one dose (the size of the read-out at that dose, not a potency): 8.04%
Compound 4: middle estimate off by 0 percentage points, on the low side; the range from low to high includes it.
By their numbers in this assay, from the lowest: compounds 1, 3, 4 and 2 (each within the scatter of the next).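

For the compounds shown here, this is the first step read at this position: in this assay, aminomethyl in place of the group of 4 heavy atoms on the saturated chain carbon gives a number 0.9 percentage points lower from compound 2 to compound 4 (within the scatter). At the one dose given, this change therefore produces no difference that can be told from the scatter. Nothing measured on the compounds explains this result.

As far as these compounds go, it remains open whether a carboxylic acid or a longer chain in place of aminomethyl would move the read-out beyond the scatter. One dose also leaves any difference in potency unresolved.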